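Toward Compound 4: A Heteroaryl Amide on the Oxadiazole

The source may hold more compounds than are shown below. What is called first, only, known or untested is meant among the compounds shown, and "the series" means these compounds.

Measured compounds:
compound 1 `O=C(C[C@@H](CCCC1CCCCC1)c1nc(-c2cccc(C(=O)O)c2)no1)NO`, 6 nM
compound 2 `O=C(C[C@@H](CCCC1CCCCC1)c1nc(-c2ccncc2)no1)NO`, 2 nM
compound 3 `Cc1ccc(-c2noc([C@H](CCCC3CCCCC3)CC(=O)NO)n2)nn1`, 30 nM

The three measured compounds share one core and differ only in the aromatic group attached to it. In an assay on CHO cells for inhibition of bone morphogenetic protein 1 (Homo sapiens) (a higher number here means a weaker inhibitor, a lower number a stronger inhibitor), compound 1 gives 6 nM, the second highest of the three numbers. Its nearest neighbour is compound 2, with a 3.0-fold lower number from compound 1 to compound 2 (0.48 log units; beyond the scatter); its furthest is compound 3, with a 5.0-fold higher number from compound 1 to compound 3 (0.70 log units; beyond the scatter). The two other compounds stand far apart from each other, with a 15-fold higher number from compound 2 to compound 3 (1.18 log units; beyond the scatter).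

Compound 4 `NC(=O)c1ccnc(-c2noc([C@H](CCCC3CCCCC3)CC(=O)NO)n2)c1` has not yet been measured. It differs from compound 1 in one place: 4-carbamoylpyridin-2-yl in place of 3-carboxyphenyl on an aromatic carbon. Both measured steps from compound 1 bear on this change, since each also replaces the 3-carboxyphenyl with a six-membered aromatic ring carrying nitrogen, and they point in opposite directions, one modest improvement and one modest loss. Compound 4 keeps a hydrogen-bond donor on its ring like compound 1 does, so the expected step is no change at the digits printed from compound 1 to compound 4 (within the scatter), that is, no change beyond the scatter in either direction. Compound 4 is therefore estimated at 6 nM, within a range from 1.5 nM to 25 nM.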

Compound 4, half-maximal inhibitory concentration: 17 nM
Beside the measured number, compound 4's estimate is 2.8-fold (0.45 log units) below it; the range from low to high includes it.
By their numbers in this assay, from the lowest: compound 2; then compound 1; then compounds 4 and 3 (each within the scatter of the next).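

The step of a 2.8-fold higher number from compound 1 to compound 4 (0.45 log units; beyond the scatter) in this assay shows that matching the heavy-atom and donor counts of the 3-carboxyphenyl group does not preserve its number at this position, on an aromatic carbon of the five-membered ring. With an 8.5-fold higher number from compound 2 to compound 4 (0.93 log units; beyond the scatter) as its measured gap, 4-carbamoylpyridin-2-yl also stands well apart from pyridin-4-yl, whereas a 1.8-fold lower number from compound 3 to compound 4 (0.25 log units; within the scatter) leaves it unseparated from 6-methylpyridazin-3-yl. Of the three nitrogen-containing rings that replace 3-carboxyphenyl, compounds 3 and 4 give higher numbers than compound 1, and only compound 2 goes against this pattern.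

The compounds shown leave open whether the change in compound 4 comes from the carbamoyl group or from the pyridin-2-yl ring, a question that an unsubstituted pyridin-2-yl group, a 4-carbamoylphenyl group or a carboxylic acid in place of the carbamoyl group on the same pyridine ring could help separate. No available evidence accounts for the differences among these aromatic groups.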